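This account rests on a few compounds, and the source may have more. Where it says the series, first, only, none or still open, it means among the compounds named here.

In a functional assay on A549 cells (Homo sapiens) for antiproliferative activity, read by MTT assay, with a stated time of 48 h (on this read-out lower numbers stand for stronger inhibition and higher numbers for weaker inhibition), compound 1 `CCN(CC)Cc1ccc2c(c1O)-c1ccc(cc1O)CCc1ccc(O)c(c1)Oc1ccc(cc1)CC2` gives 5740 nM and compound 2 `CN1CCN(Cc2ccc3c(c2O)-c2ccc(cc2O)CCc2ccc(O)c(c2)Oc2ccc(cc2)CC3)CC1` gives 5590 nM, so the two stand level. Compound 3 `CCN(CC)Cc1cc2cc(c1O)Oc1ccc(cc1)CCc1ccc(CN(CC)CC)c(O)c1-c1ccc(cc1O)CC2` differs from compound 1 by one change, (diethylamino)methyl in place of hydrogen on an aromatic carbon, ortho to a hydroxy group: (diethylamino)methyl in place of hydrogen on an aromatic carbon. Within the data shown here, the only measured step, a 1.0-fold lower number from compound 1 to compound 2 (0.01 log units; within the scatter), exchanges diethylamino for 4-methylpiperazin-1-yl and adds no second group, so it bears only loosely and gives no size for this addition. Nothing beyond the scatter is therefore expected in this assay, with wide uncertainty. The expected change is a 1.1-fold lower number from compound 1 to compound 3 (0.06 log units; within the scatter). For compound 3 the estimate is 5000 nM, within an expected range of 1800 nM to 14000 nM.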

Compound 3, half-maximal inhibitory concentration: 3780 nM
The estimate for compound 3 lay 1.3-fold (0.12 log units) above the measured number; measured number inside the range.
By their numbers in this assay, from the lowest: compounds 3, 2 and 1 (each within the scatter of the next).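

Placed on the aromatic carbon ortho to a hydroxy group, (diethylamino)methyl is tolerated in this assay, with a 1.5-fold lower number from compound 1 to compound 3 (0.18 log units; within the scatter). The shared core therefore accepts this added group at this position with no shift beyond the scatter, which the earlier exchange of amines could not show. No measurement on hand offers an explanation for this result. On these data alone, it remains open whether morpholin-4-ylmethyl or a carboxylic acid at the same position would also stay level, or would move the number beyond the scatter.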